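The source may report more compounds than this note shows. Statements on the series, on what has been measured and on what is new or still open speak of the compounds shown alone.

Measured compounds in a functional assay on COLO 205 cells (Homo sapiens) for cytotoxicity, read by MTT assay, with a stated time of 72 h; on this read-out lower numbers stand for stronger inhibition and higher numbers for weaker inhibition:
compound 1 `COc1cccc(/C=C/C(=O)Nc2cc(OC)c(OC)c(OC)c2)c1` gives 4200 nM
compound 2 `COc1ccc(C(=O)c2cc(OC)c(OC)c(OC)c2)cc1NC(=O)/C=C/c1cc(OC)c(OC)c(OC)c1` gives 5200 nM
compound 3 `COc1cccc(/C=C/C(=O)Nc2cc(C(=O)c3cc(OC)c(OC)c(OC)c3)ccc2OC)c1` gives 5100 nM

The three numbers lie close together. Compound 3 stands second highest of the three, with compound 2 nearest and compound 1 furthest; both gaps fall within the usual scatter, so no order among compounds 1, 2 and 3 can be read from this assay. For the measured compounds named here, the one single-point step that is measured, a 1.0-fold lower number from compound 2 to compound 3 (0.01 log units; within the scatter), is itself within the scatter: exchanging the 3,4,5-trimethoxyphenyl group on the ethenyl chain for 3-methoxyphenyl left the number essentially unchanged.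

Compound 4 `COc1cc(/C=C/C(=O)Nc2cc(C(=O)c3cc(OC)c(OC)c(OC)c3)ccc2OC)ccc1F` differs from compound 3 in one place: fluoro in place of hydrogen on an aromatic carbon. Going by the values given here, no measured step replaces an aromatic hydrogen by fluoro, so nothing here bears directly on the change. What is known is that a much larger change on the same aryl group, a 1.0-fold lower number from compound 2 to compound 3 (0.01 log units; within the scatter), moved the number only within the scatter, and that all three measured numbers sit in a narrow band. On that basis no step beyond the scatter is expected for compound 4 in this assay, in either direction; the expected step from compound 3 is a 1.0-fold lower number from compound 3 to compound 4 (0.01 log units; within the scatter).

Compound 4 is therefore estimated at 5000 nM in this assay, with a range of 2500 nM to 10000 nM.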

Compound 4, half-maximal inhibitory concentration: 11800 nM
Compound 4: the middle estimate sits 2.4-fold (0.37 log units) below what was measured; measured number above the stated range.
By their numbers in this assay, from the lowest: compounds 1, 3 and 2 (each within the scatter of the next); then compound 4.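

In this assay, for the compounds shown here, a change on the aryl group of the ethenyl chain now moves the number beyond the scatter for the first time (a 2.3-fold higher number from compound 3 to compound 4 (0.36 log units; beyond the scatter)), and the step is modest. It comes from a single fluoro on an aromatic carbon, ortho to a methoxy group and para to a large group. The comparison with the trimethoxy compound gives a step of the same kind (a 2.3-fold higher number from compound 2 to compound 4 (0.36 log units; beyond the scatter)), while the larger exchange of 3,4,5-trimethoxyphenyl for 3-methoxyphenyl stayed within the scatter (a 1.0-fold lower number from compound 2 to compound 3 (0.01 log units; within the scatter)), so across these compounds the size of the exchanged group does not track the size of the step, and no measurement given here accounts for the fluoro step.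

As far as these compounds go, it remains open whether the higher number belongs to fluoro specifically or would also follow from another group at this place, such as chloro, hydroxy or an amine. From the compounds shown here alone, it is also open whether the same exchange to 4-fluoro-3-methoxyphenyl would give a comparable step on the core of compound 1.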